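The source may report more compounds than this note shows. Statements on the series, on what has been measured and on what is new or still open speak of the compounds shown alone.

In a functional assay (aorta) with Rattus norvegicus as the target (on this read-out lower numbers stand for an effect already at smaller amounts and higher numbers for an effect only at larger amounts of compound), compound 3 `CC(C)[C@@H](N)C(=O)Nc1cc2cc[nH]c(=O)c2cc1Cl` stands without a number, its entry being "not determined" (no result reported) and the step to compound 4 `CN1CCC(C(=O)Nc2cc3cc[nH]c(=O)c3cc2Cl)CC1` therefore has no measured starting point. The structural change is 1-methylpiperidin-4-yl in place of 1-amino-2-methylpropyl on a carbonyl carbon and amounts to 1-methylpiperidin-4-yl in place of 1-amino-2-methylpropyl on a carbonyl carbon. Only two relatives with the shared core carry numbers. Compound 1 `CC(C)C[C@@H](N)C(=O)Nc1cc2cc[nH]c(=O)c2cc1Cl` gives 700 nM and compound 2 `O=C(Nc1cc2cc[nH]c(=O)c2cc1Cl)[C@H]1CCCN1` gives 1120 nM in the same test. Going by the values given here, the one measured step of a 1.6-fold higher number from compound 1 to compound 2 (0.20 log units; within the scatter) lies within the scatter and does not cover this change, so no step beyond the scatter is expected in this assay and no direction can be argued. Compound 4 is estimated at 900 nM and expected to fall from 250 nM to 3500 nM when measured.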

Compound 4, half-maximal effective concentration: 250 nM
The estimate for compound 4 lay 3.6-fold (0.56 log units) above the measured number; low and high end bracket the measured number.
By their numbers in this assay, from the lowest: compound 4; then compounds 1 and 2 (each within the scatter of the next).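

In this assay, going by these compounds alone, the 1-methylpiperidin-4-yl group on the carbonyl carbon gives the first steps beyond the scatter at this position (a 4.5-fold lower number from compound 2 to compound 4 (0.65 log units; beyond the scatter); a 2.8-fold lower number from compound 1 to compound 4 (0.45 log units; beyond the scatter)). Compound 4 thus has the lowest number of the three compounds with values, showing that this place accepts a six-membered non-aromatic ring whose group has 0 hydrogen-bond donors. No available data explain why this change lowers the number. The steps from compound 3 cannot be read, as it has no result. From the compounds shown here alone, it remains open whether the methyl on the ring nitrogen matters, and how a piperidin-4-yl without that methyl or a morpholine ring would read at this place.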